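Moving the ester and swapping its acid: cytotoxicity

The source may hold more compounds than are shown below. What is called first, only, known or untested is meant among the compounds shown, and "the series" means these compounds.

Compound 1: `C=C1CC[C@@H]2[C@](C)(COC(=O)/C=C/c3ccccc3)[C@H](O)CC[C@@]2(C)[C@@H]1C/C=C1\C=COC1=O` with 271000 nM
Compound 2: `C=C1CC[C@@H]2[C@](C)(COC(=O)c3cccnc3)[C@H](O)CC[C@@]2(C)[C@@H]1C/C=C1\C=COC1=O` with 2050000 nM
Compound 3: `C=C1CC[C@@H]2[C@](C)(CO)[C@H](OC(=O)/C=C/c3ccccc3)CC[C@@]2(C)[C@@H]1C/C=C1\C=COC1=O` with 179000 nM

All three compounds were tested in an ADME assay on HepG2 2.2.15 cells (Homo sapiens) for cytotoxicity, read by MTT assay; on this read-out lower numbers stand for higher toxicity in this test and higher numbers for lower toxicity in this test. Compound 1 and compound 2 share a core and differ only in the acid part of their ester: pyridin-3-yl in place of 2-phenylethenyl on a carbonyl carbon. That change gave a 7.6-fold higher number from compound 1 to compound 2 (0.88 log units; beyond the scatter), so compound 2 was the less toxic of the pair in this assay.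

Compound 3 has the same atoms as compound 1 joined differently; the difference between the two cores is not broken down here. In this assay compound 3 gives 179000 nM, and compound 1 gives 271000 nM, two numbers within the scatter of each other, while compound 2 stands well apart with 2050000 nM.

Compound 4 is `C=C1CC[C@@H]2[C@](C)(CO)[C@H](OC(=O)c3cccnc3)CC[C@@]2(C)[C@@H]1C/C=C1\C=COC1=O`. It stands to compound 3 as compound 2 stands to compound 1: pyridin-3-yl in place of 2-phenylethenyl on a carbonyl carbon. The place is the same in both pairs, a carbonyl carbon whose other neighbour is an oxygen next to a carbonyl group, so this is the same change on a differently joined core.

The expectation for compound 4 rests on compound 3 with 179000 nM and on the step of a 7.6-fold higher number from compound 1 to compound 2 (0.88 log units; beyond the scatter). Because the step of a 7.6-fold higher number from compound 1 to compound 2 (0.88 log units; beyond the scatter) was modest and the core here differs, the expected step is a 6.7-fold higher number from compound 3 to compound 4 (0.83 log units; beyond the scatter), of similar size but with room for it to be smaller. Compound 4 is therefore estimated at 1200000 nM in this assay, likely between 400000 nM and 3500000 nM.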

Compound 4, half-maximal cytotoxic concentration: 337000 nM
Compound 4: middle estimate off by 3.6-fold (0.55 log units), on the high side, and the stated range ends above it.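

On the core of compound 3, in this assay, the same swap of 2-phenylethenyl for pyridin-3-yl gave a 1.9-fold higher number from compound 3 to compound 4 (0.27 log units; within the scatter), so here the change cannot be told apart from repeat-to-repeat variation. The size of the step therefore did not carry over from one core to the other, and a step measured on one core is not a safe guide to the other in this series: the same change on two cores in this assay, a 7.6-fold higher number (0.88 log units; beyond the scatter) from compound 1 to compound 2 and a 1.9-fold higher number (0.27 log units; within the scatter) from compound 3 to compound 4, 4.0-fold (0.60 log units) apart, beyond the scatter of two such steps

For the compounds shown here, this comparison rests on only two pairs and one swap, so it shows that the core matters for this change but not what about the two cores produces the gap, nor whether any other swap would behave in the same way.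

The compounds shown leave open whether a plain phenyl, a longer saturated chain or an acid part carrying an amine would also give steps that differ between the two cores. They also leave open whether a compound with a second ester in place of the free hydroxyl group would follow either core.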